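From Phenyl to Furan-2-yl on a Saturated Ring Carbon

The source may hold more compounds than are shown below. What is called first, only, known or untested is meant among the compounds shown, and "the series" means these compounds.

In an ADME assay on HL-60 cells (Homo sapiens) for cytotoxicity (a higher number here means a weaker inhibitor, a lower number a stronger inhibitor), compound 3 `CC(=O)N1N=C(c2ccc(F)cc2)OC1c1ccccc1` gives 31.3 ug/mL. Compound 2 `O=C(N/N=C/c1ccco1)c1ccc(F)cc1` gives 27 ug/mL, and the two values lie within the usual scatter of each other. Compound 1 `CN(C)c1ccc(/C=N/NC(=O)c2ccc(F)cc2)cc1` is reported only as a limit, > 31.2 ug/mL.

Compound 4 `CC(=O)N1N=C(c2ccc(F)cc2)OC1c1ccco1` differs from compound 3 by carrying furan-2-yl in place of phenyl on a saturated ring carbon. Among the compounds with values here, no measured pair shows this exchange, so no step beyond the scatter is expected in this assay. The estimate for compound 4 is 27 ug/mL, with an expected range of 13 ug/mL to 55 ug/mL. This estimate amounts to an expected step of a 1.2-fold lower number from compound 3 to compound 4 (0.06 log units; within the scatter).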

Compound 4, half-maximal inhibitory concentration: 24 ug/mL
For compound 4 the middle estimate is 1.1-fold (0.05 log units) above the measured one; measured number inside the range.
By their numbers in this assay, from the lowest: compounds 4, 2 and 3 (each within the scatter of the next).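

Within the data shown here, compound 4 gives the first direct reading at this position: in this assay furan-2-yl in place of phenyl on the saturated ring carbon gives a 1.3-fold lower number from compound 3 to compound 4 (0.12 log units; within the scatter). The hydrogen-bond acceptor that enters with furan-2-yl therefore leaves the number within the scatter of compound 3. Compound 1 is reported only as a limit, so it adds no number to this reading: the limit of > 31.2 ug/mL in this assay, at which 1 of the 4 values shown sits.

The compounds shown leave open whether a different group on this carbon, such as an amine or a longer chain, would give a step beyond the scatter.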